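Trimming the Side Group: From Oxanyl to Bare Ring

The source may hold more compounds than are shown below. What is called first, only, known or untested is meant among the compounds shown, and "the series" means these compounds.

Of the compounds shown here, two sharing one core have been measured in a physicochemical assay for lipophilicity, using the shake flask method, at pH 7.4; a higher number here means a more lipophilic compound, a lower number a more polar compound. Compound 1 `CC(C)c1ccn2ncnc(N[C@H]3CC[C@H](N(C)C)CC3)c12` carries an isopropyl group and gives 1.3. Among the measured compounds shown here, compound 2 `CN(C)[C@H]1CC[C@H](Nc2ncnn3ccc(C4CCOCC4)c23)CC1` carries an oxan-4-yl group in the same position and gives 0.5, the lower of the two numbers, with compound 1 as its only neighbour. For the measured compounds named here, the one measured step, a number 0.80 log units lower from compound 1 to compound 2 (beyond the scatter), shows that exchanging the group at that aromatic carbon moves the read-out by a modest amount.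

Compound 3 `CN(C)[C@H]1CC[C@H](Nc2ncnn3cccc23)CC1` drops the group entirely: hydrogen in place of oxan-4-yl on an aromatic carbon. Going by the values given here, no measured step removes a substituent from this carbon, so the known step bears on it only indirectly, by showing that this position responds to change. Since the swap from compound 1 to compound 2 shifted the value by a number 0.80 log units lower from compound 1 to compound 2 (beyond the scatter), a step of comparable or smaller size is expected here, most likely downward. For compound 3 a value of 0.1 is estimated, within -0.5 to 0.7. The expected step is a number 0.40 log units lower from compound 2 to compound 3 (beyond the scatter).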

Compound 3, distribution coefficient: 0
Beside the measured number, compound 3's estimate is 0.10 log units above it; the range from low to high includes it.
By their numbers in this assay, from the lowest: compound 3; then compound 2; then compound 1.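

Taking the group off this aromatic carbon gives a number 0.50 log units lower from compound 2 to compound 3 (beyond the scatter) when the group is oxan-4-yl, and a number 1.30 log units lower from compound 1 to compound 3 (beyond the scatter) when it is isopropyl, both read in this assay. The earlier pair could only rank two groups against each other, whereas these steps add a reference point: compound 3, with plain hydrogen at this carbon, has the lowest number of the three, and both groups stand above it by an amount that depends on which group it is. The data offer no measured explanation for the size of either step.

As far as these compounds go, what remains open is whether hydrogen truly marks the low end at this carbon, or whether a group such as a carboxylic acid or an amine would bring the number below that of compound 3, and whether a longer alkyl chain would lift it past that of compound 1. The compounds shown also share one core and vary in only one place, so they leave open whether the same steps would appear on a different core.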